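The source may report more compounds than this note shows. Statements on the series, on what has been measured and on what is new or still open speak of the compounds shown alone.

Of the compounds shown here, three have so far been measured in a functional assay on LS174T cells (Homo sapiens) for inhibition, with a stated time of 4 days, tested at 1 uM; on this read-out lower numbers stand for a weaker effect and higher numbers for a stronger effect at the one concentration tested. Compound 1 `Fc1cccc(F)c1C#Cc1ccc2[nH]ccc2c1` gives 52.9%. Compound 2 `Cn1ccc2cc(C#Cc3c(F)cccc3F)ccc21` gives 77.7%, a step of a number 24.8 percentage points higher from compound 1 to compound 2 (beyond the scatter) made by methyl in place of hydrogen on an aromatic nitrogen. Compound 3 `Fc1cccc(F)c1C#Cc1ccc2cn[nH]c2c1` gives 81.5%; the difference between its core and the core of compound 1 is not broken down here. Compound 4 `Cn1ncc2ccc(C#Cc3c(F)cccc3F)cc21` has not yet been measured. Going by the values given here, it differs from compound 3 by methyl in place of hydrogen on an aromatic nitrogen, the same kind of change as the one to compound 2, though here the five-membered aromatic ring holds 2 nitrogen and the methyl sits next to the ring nitrogen, whereas in compound 2 that ring holds 1 nitrogen. A step of a number 8.5 percentage points higher from compound 3 to compound 4 (within the scatter) is expected, resting on a number 24.8 percentage points higher from compound 1 to compound 2 (beyond the scatter) but tempered because compound 3 already gives 81.5% and the read-out leaves less room above it. Compound 4 is estimated at 90%, between 78% and 98%.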

Compound 4, a percentage reported as inhibition, at one concentration (the size of the read-out at that concentration, not a potency): 85.9%
The estimate for compound 4 lay 4.1 percentage points above the measured number; measured number inside the range.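

In this assay, methyl in place of hydrogen on an aromatic nitrogen gives a number 4.4 percentage points higher from compound 3 to compound 4 (within the scatter). Set beside the earlier step, the size of this change does not carry over from one core to the other: the same change on two cores in this assay, a number 24.8 percentage points higher (beyond the scatter) from compound 1 to compound 2 and a number 4.4 percentage points higher (within the scatter) from compound 3 to compound 4, 20.4 percentage points apart, beyond the scatter of two such steps This rests on two pairs only; it shows that a step measured on one core cannot simply be assumed on the other, but it does not show what sets the two cores apart or how the change would read on a further core.

The compounds shown leave open how an ethyl group, a longer chain or a chain ending in an amine would read in place of the methyl. With a single concentration tested, they also leave open how the compounds compare in the strength of their effect at other concentrations.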